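Swapping Methyl for Trifluoromethyl in Compound 2

The source may report more compounds than this note shows. Statements on the series, on what has been measured and on what is new or still open speak of the compounds shown alone.

In a functional assay on HCT-15 cells (Homo sapiens) for inhibition, read by sulforhodamine B assay, with a stated time of 48 h, tested at 50 uM (a higher number here means more inhibition of growth at the concentration tested, a lower number less inhibition of growth), compound 2 (`Cc1ccc(F)c(C(=O)c2ccc3nc(NC(=O)C(F)(F)F)cn3c2)c1`) gives 91.2% and cannot be told apart from compound 1 (`O=C(c1ccc2nc(NC(=O)C(F)(F)F)cn2c1)c1ccc(C(F)(F)F)cc1F`) at 100% while compound 3 (`Cc1ccc(C(=O)c2ccc3nc(NC(=O)C(F)(F)F)cn3c2)cc1F`) at 65.5% lies clearly lower. Compound 4 (`O=C(c1ccc2nc(NC(=O)C(F)(F)F)cn2c1)c1cc(C(F)(F)F)ccc1F`) is still unmeasured. It differs from compound 2 by one change (trifluoromethyl in place of methyl on an aromatic carbon) on an aromatic carbon para to a fluoro group. Within the data shown here, the only measured step of a number 25.7 percentage points lower from compound 2 to compound 3 (beyond the scatter) is modest and swaps no methyl for trifluoromethyl, so it offers only a loose guide. Compound 1 gives 100% with a trifluoromethyl on its ring, so no step beyond the scatter is expected. The estimated step is a number 0.8 percentage points higher from compound 2 to compound 4 (within the scatter) and would be no real change. Compound 4 is expected at 92% with an estimated range from 72% to 100% as the likely span.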

Compound 4, percent growth inhibition at one concentration: 91.7%
The estimate for compound 4 lay 0.3 percentage points above the measured number, within the range that was stated.
By their numbers in this assay, from the lowest: compound 3; then compounds 2, 4 and 1 (each within the scatter of the next).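

In this assay, trifluoromethyl in place of methyl on this aromatic carbon, para to a fluoro group, gives a number 0.5 percentage points higher from compound 2 to compound 4 (within the scatter) and so is no real change, even with four heavy atoms entering where one leaves. The earlier step, a number 25.7 percentage points lower from compound 2 to compound 3 (beyond the scatter), moved groups around the ring, whereas this one keeps their places and changes only the group. Nothing measured here explains this result.

Going by these compounds, whether an amine or a carboxylic acid on this carbon would give a similar result remains open. Testing at a single concentration also leaves open whether compound 2 and compound 4 would differ at lower concentrations.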